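Trifluoromethylphenyl carbonyl analogues: cytotoxicity notes

The source may hold more compounds than are shown below. What is called first, only, known or untested is meant among the compounds shown, and "the series" means these compounds.

Measured so far:
compound 1 `COc1cc(-c2nn(-c3cccc(NC(=O)Nc4cc(C(F)(F)F)cc(C(F)(F)F)c4)c3)cc2-c2ccncc2)ccc1Cl`: 3390 nM
compound 2 `COc1cc(-c2nn(-c3cccc(NC(=O)c4cccc(C(F)(F)F)c4)c3)cc2-c2ccncc2)ccc1Cl`: > 50000 nM
compound 3 `O=C(Nc1cccc(-n2cc(-c3ccncc3)c(-c3ccc(Cl)c(O)c3)n2)c1)Nc1ccc(Cl)c(Cl)c1`: 26300 nM

In a functional assay on KM12 cells (Homo sapiens) for inhibition, read by sulforhodamine B assay, with a stated time of 48 h (a lower number here means that less compound is tolerated, a higher number that more compound is tolerated), compound 1 gives 3390 nM and compound 3 gives 26300 nM. Compound 2 reaches only a limit of this assay, > 50000 nM, and stands at the limit of > 50000 nM in this assay, at which 1 of the 3 values shown sits, so no number is known for it. Compound 4 `COc1cc(-c2nn(-c3cccc(NC(=O)Nc4cccc(C(F)(F)F)c4)c3)cc2-c2ccncc2)ccc1Cl` is not yet measured. It differs from compound 2 by (3-(trifluoromethyl)phenyl)amino in place of 3-(trifluoromethyl)phenyl on a carbonyl carbon. Compound 1 and compound 3 both carry an amino group of this kind on the carbonyl carbon and both give measurable values, while compound 2 gives none. A step to lower concentration, beyond the scatter, is therefore expected: an at least 5.0-fold lower number from compound 2 to compound 4 (0.69 log units; beyond the scatter). The estimate for compound 4 is 10000 nM, within a range from 3000 nM to 40000 nM.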

Compound 4, concentration lethal to 50% of the cells: > 50000 nM
Compound 4 ended at the assay's limit (the forecaster's own chance of this, stated with the estimate: 15%); at least 5.0-fold (0.69 log units) between middle value and limit.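

In this assay compound 4 sits at a limit, > 50000 nM, which is not a number, so the amino group on the carbonyl carbon does not by itself give a measurable value in this series. The step between compound 2 and compound 4 cannot be read, because both rest at the same limit: the limit of > 50000 nM in this assay, at which 2 of the 4 values shown sit.

Hydrogen in place of trifluoromethyl on an aromatic carbon gives an at least 14-fold higher number from compound 1 to compound 4 (1.16 log units; beyond the scatter), so the measurable value of compound 1 depends on that second trifluoromethyl. On these data alone, whether a nitrile or a carboxylic acid on that aromatic carbon would also give a measurable value stays open.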